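From fluoro to chloro: compound 1 to compound 3

The source may report more compounds than this note shows. Statements on the series, on what has been measured and on what is new or still open speak of the compounds shown alone.

Measured in a functional assay on T98G cells (Homo sapiens) for cytotoxicity, read by MTT assay, with a stated time of 48 h; on this read-out lower numbers stand for stronger inhibition and higher numbers for weaker inhibition
- compound 1 `C/C(=N/NC(=S)Nc1ccccc1F)c1ccccn1` 3.1 nM
- compound 2 `C/C(=N\NC(=S)Nc1ccccc1F)c1ccccn1` 3.1 nM

In this assay, within the data shown here, compound 1 gives 3.1 nM and stands level with compound 2 , the only other measured compound. Among the measured compounds shown here, the single measured step, no change at the digits printed from compound 1 to compound 2 (within the scatter), goes with the fact that compounds 1 and 2 differ only in the configuration as drawn, so it concerns the double bond and offers no direct measure of a halogen change. Compound 3 `C/C(=N/NC(=S)Nc1ccccc1Cl)c1ccccn1` carries chloro in place of fluoro on an aromatic carbon, with chloro in place of fluoro on an aromatic carbon, and keeps the configuration drawn for compound 1 . For the measured compounds named here, with no change at the digits printed from compound 1 to compound 2 (within the scatter) as the only guide, no direction can be assigned, and no shift beyond the scatter is expected in this assay. The expected step is a 1.0-fold lower number from compound 1 to compound 3 (0.01 log units; within the scatter). For compound 3 the estimated value is 3 nM, with an expected range from 0.8 nM to 12 nM.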

Compound 3, half-maximal inhibitory concentration: 1.1 nM
Compound 3: middle estimate off by 2.7-fold (0.44 log units), on the high side; the measured number falls inside the stated range.
By their numbers in this assay, from the lowest: compound 3; then compounds 1 and 2 (each within the scatter of the next).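

In this assay, among these compounds, the halogen on an aromatic carbon ortho to a large group is the first place where a change moves the number beyond the scatter: chloro in place of fluoro goes with a 2.8-fold lower number from compound 1 to compound 3 (0.45 log units; beyond the scatter). Among the compounds shown here, the only earlier step, no change at the digits printed from compound 1 to compound 2 (within the scatter), concerned the configuration of the double bond and said nothing about this position, which now shows a modest preference for chloro over fluoro. Nothing shown gives a cause for this step.

Still open, on these data alone, is whether bromo, methyl or an amine on this carbon would take the number further down or back up. Also open, as far as these compounds go, is whether the configuration of the double bond stays without consequence once chloro replaces fluoro.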